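Sulfamoyl Acid to Carbamoyl Diacid: a Permeability Outlook

The compounds below may be only part of what the source reports. "The series", "measured", "known", "first", "only" and "open" are said of these compounds alone.

Measured so far:
Compound 1, `C[C@@H](N[C@H]1CCN(c2ccc(S(=O)(=O)NCC(=O)O)cc2)C1)c1cccc2ccccc12`, gives 16 nm/s in an ADME assay on MDCK cells (Canis lupus familiaris) for inhibition, read by LC-MS, with a stated time of 60 min, tested at 3 uM, in the presence of a further agent that is not named here; on this read-out higher numbers stand for higher permeability and lower numbers for lower permeability.
Compound 2, `C[C@@H](N[C@H]1CCN(c2ccc(C(=O)NCCS(=O)(=O)O)cc2)C1)c1cccc2ccccc12`, gives 4 nm/s.
Compound 3, `C[C@@H](N[C@H]1CCN(c2ccc(C(=O)N[C@H](CCCCN)C(=O)O)cc2)C1)c1cccc2ccccc12`, gives 4 nm/s.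

Compound 1 stands highest of the three measured numbers, and both other compounds lie beyond the scatter below it: a 4.0-fold lower number from compound 1 to compound 2 (0.60 log units; beyond the scatter), and a 4.0-fold lower number from compound 1 to compound 3 (0.60 log units; beyond the scatter). Between the two lower compounds the step is no change at the digits printed from compound 2 to compound 3 (within the scatter).

Compound 4, `C[C@@H](N[C@H]1CCN(c2ccc(C(=O)N[C@H](CC(=O)O)C(=O)O)cc2)C1)c1cccc2ccccc12`, is the next member of the series. Its difference from compound 1 is (1,2-dicarboxyethyl)carbamoyl in place of (carboxymethyl)sulfamoyl on an aromatic carbon. Both measured steps from compound 1 bear on this change, since each of them also puts a substituted carbamoyl group in place of the (carboxymethyl)sulfamoyl group, and each lowered the number by the same modest amount. The step to compound 4 is therefore expected to fall in the same direction and of a similar size, a 4.6-fold lower number from compound 1 to compound 4 (0.66 log units; beyond the scatter), with the reading for compound 4 estimated at 3.5 nm/s, in a range from 1.5 nm/s to 8 nm/s.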

Compound 4, apparent permeability: 9 nm/s
For compound 4 the middle estimate is 2.6-fold (0.41 log units) below the measured one, outside the stated range (above it).
By their numbers in this assay, from the lowest: compounds 2 and 3 (each within the scatter of the next); then compounds 4 and 1 (each within the scatter of the next).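

In this assay, among the compounds shown here, a carbamoyl group in place of the (carboxymethyl)sulfamoyl group on this aromatic carbon does not have to bring the loss seen with the earlier compounds: (1,2-dicarboxyethyl)carbamoyl gives a 1.8-fold lower number from compound 1 to compound 4 (0.25 log units; within the scatter) and so stays level with the starting compound. The carbamoyl compounds also do not share one level, since what is carried on the amide-type nitrogen separates them, with a 2.3-fold higher number from compound 3 to compound 4 (0.35 log units; beyond the scatter) for carboxy in place of 3-aminopropyl and a 2.3-fold higher number from compound 2 to compound 4 (0.35 log units; beyond the scatter) for 1,2-dicarboxyethyl in place of 2-sulfoethyl. No measurement is at hand to explain these steps.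

The compounds shown leave open how the simpler (carboxymethyl)carbamoyl group would read, which would set the sulfamoyl-to-carbamoyl exchange apart from the change in the chain. They also leave open whether a longer chain bearing two carboxylic acids, such as 1,3-dicarboxypropyl, would hold this level.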